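Swapping the Amide Aryl Group in an Antiproliferative Series

The source may hold more compounds than are shown below. What is called first, only, known or untested is meant among the compounds shown, and "the series" means these compounds.

Compound 1 `CCc1ccc(C(=O)Nc2ccc3nc(N4CCN(CC)CC4)cc(C)c3c2)cc1` — 9850 nM
Compound 2 `CCc1ccccc1C(=O)Nc1ccc2nc(N3CCN(CC)CC3)cc(C)c2c1` — 23900 nM

Both compounds were tested in a functional assay on SK-BR-3 cells (Homo sapiens) for antiproliferative activity, read by MTT assay, with a stated time of 72 h; a higher number here means a weaker inhibitor, a lower number a stronger inhibitor. Among the compounds with values here, compound 2 gives the highest of the two numbers; its nearest neighbour is compound 1, and the only measured step, a 2.4-fold higher number from compound 1 to compound 2 (0.38 log units; beyond the scatter), is modest but beyond the scatter, arising from 2-ethylphenyl in place of 4-ethylphenyl on a carbonyl carbon.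

Compound 3 `CCN1CCN(c2cc(C)c3cc(NC(=O)c4ccc5ccccc5n4)ccc3n2)CC1` has not yet been measured. It differs from compound 2 by quinolin-2-yl in place of 2-ethylphenyl on a carbonyl carbon. Within the data shown here, no measured step bears directly on this change: the one step in hand concerns only where the ethyl sits on the phenyl ring, not the exchange of that ring for a different aromatic group. The step from compound 1 to compound 2 shows that the amide aryl group does move the number, so some change is plausible, but its direction cannot be read from the data.

Compound 3 is therefore expected near compound 2, with the step of a 1.6-fold lower number from compound 2 to compound 3 (0.20 log units; within the scatter) estimated as small and uncertain in direction. The estimate for compound 3 is 15000 nM, within the range 4000 nM to 50000 nM.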

Compound 3, half-maximal inhibitory concentration: 3760 nM
Estimate against measurement, compound 3: 4.0-fold (0.60 log units) above; the whole stated range lies above it.
By their numbers in this assay, from the lowest: compound 3; then compound 1; then compound 2.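

On the carbonyl carbon of the amide, the ethylphenyl groups are not the best of what the series shows, since quinolin-2-yl gives a 6.4-fold lower number from compound 2 to compound 3 (0.80 log units; beyond the scatter) in this assay and also improves on the better ethylphenyl isomer with a 2.6-fold lower number from compound 1 to compound 3 (0.42 log units; beyond the scatter) in the same test. Within the data shown here, the earlier pair showed only that moving the ethyl group raised the number, whereas these steps show that a change at this place can take the number below both ethylphenyl compounds, leaving compound 3 lowest of the three with both of its steps beyond the scatter. The incoming group has one more ring and brings a ring nitrogen and a hydrogen-bond acceptor, but no measurement available here accounts for the gain.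

From the compounds shown here alone, whether the gain follows the ring nitrogen or the second ring stays open, and a naphthalen-2-yl group, with carbon only, or a pyridin-2-yl group, with the nitrogen in a single ring, would separate the two. Also open, going by these compounds, is whether a methoxy group or a chlorine atom on quinolin-2-yl would move the number further in this assay and whether the gain holds on other cell lines.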